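The source may report more compounds than this note shows. Statements on the series, on what has been measured and on what is new or still open speak of the compounds shown alone.

In a functional assay on HT-29 cells (Homo sapiens) for antiproliferative activity, read by XTT assay, with a stated time of 72 h (on this read-out higher numbers stand for weaker inhibition and lower numbers for stronger inhibition), three compounds sharing one core have been measured. Compound 1 `C=C(C)CCC[C@]1(C)C2=CCC[C@](C)(CC(=O)c3ccoc3)[C@H]2CC[C@H]1C` reaches only a limit, > 100000 nM. Compound 2 `C=C(C)CCC[C@]1(C)C2=CCC[C@](C)(C[C@H](OC(C)=O)C3=CC(=O)OC3O)[C@H]2CC[C@H]1C` gives 4200 nM and compound 3 `C=C(C)CCC[C@]1(C)C2=CCC[C@](C)(C[C@@H](O)C3=CC(=O)OC3O)[C@H]2CC[C@H]1C` gives 2300 nM. These two numbers lie within the scatter of each other, so no order can be drawn between them, and compound 3 stands with compound 2 as one of the two compounds with a measured number.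

Compound 4 `C=C(C)CCC[C@]1(C)C2=CCC[C@](C)(C[C@H](O)C3=CC(=O)OC3O)[C@H]2CC[C@H]1C` is the next to be measured, and it differs from compound 3 in one respect: the two compounds have the same atoms and bonds; at least one stereo element is drawn with a configuration in one of them and without one in the other: 1 of 6 stereo elements differ; a stereocentre at a saturated chain carbon is drawn R in compound 3 and S in compound 4. For the measured compounds named here, only one measured step connects to this pair, an at least 43-fold lower number from compound 1 to compound 3 (1.63 log units; beyond the scatter). That is a large step, but it exchanges a whole group rather than a configuration, so it gives no size for the inversion of a single stereocentre. Going by the values given here, no measured step isolates this change. With compound 3 at 2300 nM as the anchor, no step beyond the scatter is expected in this assay, although a moderate shift in either direction remains possible. The expected step is a 1.3-fold higher number from compound 3 to compound 4 (0.12 log units; within the scatter). For compound 4 the estimated value is 3000 nM, with an expected range of 1000 nM to 10000 nM.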

Compound 4, half-maximal inhibitory concentration: 3000 nM
For compound 4 middle estimate and measured number coincide at the digits printed, within the range that was stated.
By their numbers in this assay, from the lowest: compounds 3, 4 and 2 (each within the scatter of the next). At a limit, above all of these: compound 1.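

In this assay, the inversion of the stereocentre at the saturated chain carbon gives a 1.3-fold higher number from compound 3 to compound 4 (0.12 log units; within the scatter), and hydrogen in place of acetyl on the oxygen gives a 1.4-fold lower number from compound 2 to compound 4 (0.15 log units; within the scatter), so neither change separates these compounds, whose values all lie within the scatter of one another. The group exchange on the saturated chain carbon bound to a saturated ring carbon gives an at least 33-fold lower number from compound 1 to compound 4 (1.52 log units; beyond the scatter), a large step that now appears with both drawn configurations, alongside an at least 43-fold lower number from compound 1 to compound 3 (1.63 log units; beyond the scatter). Compound 1 stands at a limit and not at a number, so these two steps have no exact size: the limit of > 100000 nM in this assay, at which 1 of the 4 values shown sits.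

The compounds shown leave open whether an amine or a methyl ether on that chain carbon, in place of the hydroxyl, would stay within the scatter of compound 4. They also leave open whether the acetyl group, present only in compound 2, would give a similar value in the opposite configuration, and which part of the exchanged group carries the large step from compound 1.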